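Swapping the Side Group on the Saturated Ring Carbon

The compounds below may be only part of what the source reports. "The series", "measured", "known", "first", "only" and "open" are said of these compounds alone.

Three compounds share one core and differ only in the group on a saturated ring carbon. In a functional assay on the whole organism (strain Wistar albino) for inhibition, with Rattus norvegicus as the target, read by paw edema, with stated times of 30 min and 5 h, at a dose of 0.05 mmol/kg (on this read-out higher numbers stand for more inhibition at the one dose given (going by the name of the read-out) and lower numbers for less inhibition), compound 1 `NS(=O)(=O)c1ccc(N2N=C(c3cccc(O)c3)C[C@H]2c2ccc(O)cc2)cc1` gives 77.7%, compound 2 `COc1ccc([C@@H]2CC(c3cccc(O)c3)=NN2c2ccc(S(N)(=O)=O)cc2)cc1OC` gives 66.7%, and compound 3 `NS(=O)(=O)c1ccc(N2N=C(c3cccc(O)c3)C[C@H]2/C=C/c2ccccc2)cc1` gives 59.2%. Compound 3 thus carries the lowest of the three numbers, though its gap to compound 2 is within the scatter, while the steps of a number 18.5 percentage points lower from compound 1 to compound 3 (beyond the scatter) and a number 11 percentage points lower from compound 1 to compound 2 (beyond the scatter) lie beyond it. Compound 4 `NS(=O)(=O)c1ccc(N2N=C(c3cccc(O)c3)C[C@H]2c2ccco2)cc1` is not yet measured; it differs from compound 3 by furan-2-yl in place of 2-phenylethenyl on a saturated ring carbon. Among the measured compounds shown here, no measured step involves furan-2-yl, but the step of a number 18.5 percentage points lower from compound 1 to compound 3 (beyond the scatter) shows that a six-membered aromatic group at this carbon scored higher than 2-phenylethenyl, so a modest rise is expected for compound 4, a number 5.8 percentage points higher from compound 3 to compound 4 (within the scatter). Compound 4 is estimated at 65%, within 50% to 78%.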

Compound 4, a percentage reported as inhibition, in the whole organism at one dose (the size of the read-out at that dose, not a potency): 29.6%
Beside the measured number, compound 4's estimate is 35.4 percentage points above it, outside the stated range (below it).
By their numbers in this assay, from the lowest: compound 4; then compounds 3 and 2 (each within the scatter of the next); then compound 1.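

In this assay the change to furan-2-yl gives the largest drops seen at this saturated ring carbon: a number 29.6 percentage points lower from compound 3 to compound 4 (beyond the scatter) and a number 37.1 percentage points lower from compound 2 to compound 4 (beyond the scatter) and also a number 48.1 percentage points lower from compound 1 to compound 4 (beyond the scatter) in this series. So the position does not treat all aromatic rings alike, since the one five-membered ring sits beyond the scatter under all three groups holding a six-membered aromatic ring of carbon only. Nothing available explains this drop. From the compounds shown here alone, whether thiophen-2-yl, which has sulfur in place of the furan oxygen, would score like furan-2-yl stays open, as does the result for a saturated group such as cyclohexyl.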